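Cytotoxicity limits and the step to compound 4

This account rests on a few compounds, and the source may have more. Where it says the series, first, only, none or still open, it means among the compounds named here.

compound 1 `CCCCCc1cc2cn([C@H]3C[C@H](O)[C@@H](CO)O3)c(=O)nc2o1`: > 50000 nM (a limit)
compound 2 `CCCCCCc1cc2cn([C@H]3C[C@H](O)[C@@H](CO)O3)c(=O)nc2o1`: > 200000 nM (a limit)
compound 3 `CCCCCCCCc1cc2cn([C@H]3C[C@H](O)[C@@H](CO)O3)c(=O)nc2o1`: > 50000 nM (a limit)

In a functional assay on HEL cells (Homo sapiens) for cytotoxicity (on this read-out higher numbers stand for lower toxicity in this test and lower numbers for higher toxicity in this test), compound 1 stands at > 50000 nM, which is a limit and not a number. Compound 4 `C=CCCCCCCc1cc2cn([C@H]3C[C@H](O)[C@@H](CO)O3)c(=O)nc2o1` keeps the shared core and differs from compound 1 as follows: allyl in place of hydrogen on a saturated chain carbon, five bonds along the chain from an aromatic carbon. Compound 3 carries propyl in that same place, so a step that the two limits leave unreadable from compound 1 to compound 3 is the closest guide, and a step that the two limits leave unreadable from compound 1 to compound 2 also bears on it. Neither has a readable size, so no direction can be claimed. The expected change is a step that the limit leaves unreadable from compound 1 to compound 4, a rough estimate. For compound 4 the estimated value in this assay is 100000 nM, with an expected range from 40000 nM to 250000 nM.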

Compound 4, half-maximal cytotoxic concentration: > 200000 nM
Compound 4: no number, only a limit (the forecaster's own chance of this, stated with the estimate: 85%); at least 2.0-fold (0.30 log units) between middle value and limit.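

In this assay, compound 4 gives only a limit, so its steps from compound 1, compound 2 and compound 3 cannot be read. The compounds shown leave open at what concentration any of the four becomes toxic to these cells.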